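Replacing the 6-fluoropyridin-2-yl Group of Compound 3

The source may report more compounds than this note shows. Statements on the series, on what has been measured and on what is new or still open speak of the compounds shown alone.

In an ADME assay on microsomes from liver (Mus musculus) for metabolic stability (on this read-out lower numbers stand for a shorter-lived compound and higher numbers for a longer-lived compound), compound 1 (`Cc1cccc(NC(=O)c2nn(C)c(-c3ccc(F)cc3)c2C)n1`) gives 0.6 h and compound 2 (`Cc1cccc(NC(=O)c2nn(C)c(-c3ccc(C(F)(F)F)cc3)c2C)n1`) gives 3.23 h. Compound 3 (`Cc1nc(C(=O)Nc2cccc(F)n2)c(C)n1-c1ccc(F)cc1`) gives 0.617 h. This places compound 3 level with compound 1, within the scatter, and beyond the scatter from compound 2, the highest of the three numbers.

Compound 4 (`Cc1nc(C(=O)Nc2ccnc(Cl)n2)c(C)n1-c1ccc(F)cc1`), still unmeasured, carries 2-chloropyrimidin-4-yl in place of 6-fluoropyridin-2-yl on an amide-type nitrogen.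

Only one measured step exists among these compounds, and it bears on this change only loosely. That step, a 5.4-fold higher number from compound 1 to compound 2 (0.73 log units; beyond the scatter), is trifluoromethyl in place of fluoro on an aromatic carbon. It shows that one substitution can move this assay beyond the scatter, but it involves different groups at a different place. Among the measured compounds shown here, no measured step covers a change on the amide-type nitrogen, so neither the size nor the direction of this one can be read from the data. The value of compound 3 remains the only anchor, and no shift beyond the scatter is assumed, only a slight lean downward. The expected change is a 1.2-fold lower number from compound 3 to compound 4 (0.09 log units; within the scatter). Compound 4 is estimated at 0.5 h, with an expected range from 0.2 h to 1.3 h.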

Compound 4, half-life: 4.63 h
For compound 4 the middle estimate is 9.3-fold (0.97 log units) below the measured one; measured number outside the range, above it.
By their numbers in this assay, from the lowest: compounds 1 and 3 (each within the scatter of the next); then compounds 2 and 4 (each within the scatter of the next).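

Among the compounds shown here, compound 3 to compound 4 is the first step on the amide-type nitrogen, and in this assay it shows a change at this place moving the read-out upward, with a 7.5-fold higher number from compound 3 to compound 4 (0.88 log units; beyond the scatter). The earlier compounds shown here showed such a move beyond the scatter only for trifluoromethyl in place of fluoro on an aromatic carbon, so this result adds a second place where a single substitution matters, and here the entering and leaving groups match in heavy-atom count and differ in their ring hetero atoms and their halogen. Nothing available here says why the number rises so far with this exchange.

Since the ring hetero atoms and the halogen change together, the compounds shown cannot tell which of the two carries the step, and 6-chloropyridin-2-yl or 2-fluoropyrimidin-4-yl on the same nitrogen would pull them apart. Going by these compounds, it also stays open whether the chlorine can give way to a methoxy group or an amine without losing the longer half-life, and whether the same exchange holds on the core of compound 1.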